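Swapping Cyclobutyl for Phenyl at the Amine Carbon

The compounds below may be only part of what the source reports. "The series", "measured", "known", "first", "only" and "open" are said of these compounds alone.

Of the compounds shown here, two have been measured in an assay on cells for displacement of a labelled ligand from corticotropin-releasing factor receptor 1 (Homo sapiens), with a stated time of 100 min; a lower number here means a stronger inhibitor, a higher number a weaker inhibitor. Compound 1 `CCCCN(CC)Cc1c(C(F)(F)F)nc2n(-c3c(C)cc(C)cc3C)c(Cl)cn12` gives 78 nM, and compound 2 `CCN(Cc1c(C(F)(F)F)nc2n(-c3c(C)cc(C)cc3C)c(Cl)cn12)CC1CCC1` gives 16 nM. For the measured compounds named here, compound 2 therefore stands at the lowest of the two numbers, with compound 1 as its only neighbour. Going by the values given here, the single measured step, a 4.9-fold lower number from compound 1 to compound 2 (0.69 log units; beyond the scatter), went with cyclobutyl in place of propyl on a saturated chain carbon bound to an amine nitrogen, and it is the only step available here.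

Compound 3 `CCN(Cc1ccccc1)Cc1c(C(F)(F)F)nc2n(-c3c(C)cc(C)cc3C)c(Cl)cn12` differs from compound 2 by phenyl in place of cyclobutyl on a saturated chain carbon bound to an amine nitrogen. Among the compounds with values here, no measured step covers a ring replacing another ring at this position, so the step to compound 1 bears on it only loosely, as a sign that this position tolerates change. A small step is expected, a 1.9-fold higher number from compound 2 to compound 3 (0.27 log units; within the scatter), pointing toward a slightly higher number. Compound 3 is estimated at 30 nM, within a range from 10 nM to 100 nM.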

Compound 3, inhibition constant: 350 nM
Compound 3: the middle estimate sits 12-fold (1.07 log units) below what was measured, and the stated range ends below it.
By their numbers in this assay, from the lowest: compound 2; then compound 1; then compound 3.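

For the compounds shown here, the position is less forgiving than the first pair of compounds suggested: in this assay, replacing the cyclobutyl ring with a phenyl ring gives a 22-fold higher number from compound 2 to compound 3 (1.34 log units; beyond the scatter), so one ring cannot simply stand in for another here. The phenyl group also compares poorly with the open propyl chain, giving a 4.5-fold higher number from compound 1 to compound 3 (0.65 log units; beyond the scatter), which means that cyclobutyl and phenyl move the number in opposite directions from propyl. No measured evidence bears on the reason for this difference.

Cyclobutyl and phenyl differ in both ring size and aromatic character, so the compounds shown leave open which of the two goes with the higher number. A cyclohexyl group, a six-membered non-aromatic ring of carbon only, would separate them, while a pyridyl ring would test a nitrogen within the aromatic ring.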